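Swapping Methylsulfonyl for Cyano in Compound 2

The source may report more compounds than this note shows. Statements on the series, on what has been measured and on what is new or still open speak of the compounds shown alone.

Of the compounds shown here, two have so far been measured in a functional assay on MCF7 cells (Homo sapiens) for antiproliferative activity, read by CellTiter-Glo, with a stated time of 5 days; a higher number here means a weaker inhibitor, a lower number a stronger inhibitor. Compound 1 `CC1=C(c2cccc(O)c2)C(c2ccc(OC[C@@H](C)N3CCCC3)cc2)Oc2ccc(O)cc21` gives 0.2 nM. Compound 2 `CC1=C(c2ccc(S(C)(=O)=O)cc2)C(c2ccc(OC[C@H](C)N3CC[C@@H](C)C3)cc2)Oc2ccc(O)cc21` gives 27 nM, the higher of the two numbers, which makes it the weaker inhibitor of the pair. Its gap to compound 1 lies well beyond the usual scatter of repeated measurements.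

Compound 3 `CC1=C(c2ccc(C#N)cc2)C(c2ccc(OC[C@H](C)N3CC[C@@H](C)C3)cc2)Oc2ccc(O)cc21` is compound 2 with a single exchange: cyano in place of methylsulfonyl on an aromatic carbon, para to a large group (cyano in place of methylsulfonyl on an aromatic carbon). The rest of the structure stays the same. Among the compounds with values here, no measured pair of compounds shows this exchange, so the data give no direct guide to its size, and the expectation rests on the structural change alone. Neither group forms a ring or carries a net charge, and a large shift is not expected. The expected step of a 1.8-fold lower number from compound 2 to compound 3 (0.26 log units; within the scatter) is small, within the scatter, and leans slightly towards a lower number. For compound 3 the estimated value is 15 nM, with an expected range of 4 nM to 60 nM.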

Compound 3, half-maximal inhibitory concentration: 10 nM
Compound 3: middle estimate off by 1.5-fold (0.18 log units), on the high side, within the range that was stated.
By their numbers in this assay, from the lowest: compound 1; then compound 3; then compound 2.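

Within the data shown here, the exchange of 4-(methylsulfonyl)phenyl for 4-cyanophenyl gives the first direct reading of this position in this assay: the change brings a 2.7-fold lower number from compound 2 to compound 3 (0.43 log units; beyond the scatter), a modest step. This single pair shows that the number responds to what sits on this aromatic carbon, and that cyano, with 2 heavy atoms against the 4 of methylsulfonyl, costs nothing here and in fact goes with a somewhat stronger inhibitor. Nothing measured on these compounds accounts for the step, so it stands as an observation without an explanation.

Going by these compounds, one exchange gives only one direction at this position, and it remains open whether an amine, a carboxylic acid or a lone fluorine atom on the same carbon would lower the number further or raise it again. Compound 1 differs from compound 3 in more than one place, so these results cannot say how much of the gap between them belongs to this aromatic ring and how much to the amine-bearing side chain.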